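The compounds below may be only part of what the source reports. "The series", "measured", "known", "first", "only" and "open" are said of these compounds alone.

Compound 1 `CC(=O)Nc1ccc2oc(-c3ccccc3F)cc(=O)c2c1`: 205000 nM
Compound 2 `COc1cccc(-c2oc3ccc(NC(C)=O)cc3c(=O)c2O)c1`: 33300 nM

In an ADME assay on MT4 cells (Homo sapiens) for cytotoxicity, read by MTT assay, with a stated time of 4 days (a lower number here means that less compound is tolerated, a higher number that more compound is tolerated), compound 2 has the lower of the two numbers, 33300 nM, and the gap to compound 1 lies beyond the usual scatter. Compound 3 `CC(=O)Nc1ccc2oc(-c3ccccc3F)c(O)c(=O)c2c1` carries 2-fluorophenyl in place of 3-methoxyphenyl on an aromatic carbon of compound 2: 2-fluorophenyl in place of 3-methoxyphenyl on an aromatic carbon. Among the compounds with values here, no measured pair isolates this change, so the evidence is thin. Compound 1 also carries 2-fluorophenyl and gives 205000 nM, which points to a small rise in the number. The expected step is a 2.0-fold higher number from compound 2 to compound 3 (0.29 log units; within the scatter). For compound 3 the estimate is 65000 nM, with an expected range of 25000 nM to 190000 nM.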

Compound 3, half-maximal cytotoxic concentration: 171000 nM
Estimate against measurement, compound 3: 2.6-fold (0.42 log units) below, within the range that was stated.
By their numbers in this assay, from the lowest: compound 2; then compounds 3 and 1 (each within the scatter of the next).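

Replacing 3-methoxyphenyl with 2-fluorophenyl next to the ring oxygen gives a 5.1-fold higher number from compound 2 to compound 3 (0.71 log units; beyond the scatter) and shows that the group at this carbon can shift how much compound is tolerated. Adding hydroxy in place of hydrogen gives a 1.2-fold lower number from compound 1 to compound 3 (0.08 log units; within the scatter) and so makes no clear difference while 2-fluorophenyl is present. Nothing measured here explains either result.

The two aromatic groups differ in both their substituent and its place, so the compounds shown cannot separate these effects. As far as these compounds go, how a plain phenyl or an aminophenyl group would behave at this carbon remains open.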